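Adding a Third Methoxy Group and Cell Toxicity

This account rests on a few compounds, and the source may have more. Where it says the series, first, only, none or still open, it means among the compounds named here.

Compound 1 `COc1ccccc1C(=O)/C=C/c1ccc2c(c1)B(O)OC2`, compound 2 `COc1ccc(C(=O)/C=C/c2ccc3c(c2)B(O)OC3)c(OC)c1` and compound 3 `COc1ccc(C(=O)/C=C/c2ccc3c(c2)B(O)OC3)cc1OC` share one core and differ only in the methoxy groups on the ring that carries the carbonyl. In a toxicity assay on MCF-10A cells (Homo sapiens) for cytotoxicity, read by MTT assay, with a stated time of 48 h (a lower number here means a stronger inhibitor, a higher number a weaker inhibitor), compound 1 gives 9100 nM, compound 2 gives 12200 nM and compound 3 gives 13500 nM. The change methoxy in place of hydrogen on an aromatic carbon made the step of a 1.3-fold higher number from compound 1 to compound 2 (0.13 log units; within the scatter). How the core of compound 3 differs from the core of compound 1 is not broken down here.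

Compound 4 `COc1cc(C(=O)/C=C/c2ccc3c(c2)B(O)OC3)cc(OC)c1OC`, not yet measured, arises from compound 3 by the change (methoxy in place of hydrogen on an aromatic carbon). This is the same kind of change as from compound 1 to compound 2, but its place differs: here ortho to a methoxy group and meta to a large group, there meta to a methoxy group and para to a large group.

Because the step of a 1.3-fold higher number from compound 1 to compound 2 (0.13 log units; within the scatter) stayed within the scatter, a step of a 1.1-fold higher number from compound 3 to compound 4 (0.05 log units; within the scatter) is expected. Compound 4 is therefore estimated at 15000 nM in this assay, between 7000 nM and 32000 nM.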

Compound 4, half-maximal inhibitory concentration: 48500 nM
Estimate against measurement, compound 4: 3.2-fold (0.51 log units) below; measured number above the stated range.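

In this assay, the new step is a 3.6-fold higher number from compound 3 to compound 4 (0.56 log units; beyond the scatter), and it does not match the same change made earlier: the same change on two cores in this assay, a 1.3-fold higher number (0.13 log units; within the scatter) from compound 1 to compound 2 and a 3.6-fold higher number (0.56 log units; beyond the scatter) from compound 3 to compound 4, 2.7-fold (0.43 log units) apart, beyond the scatter of two such steps. This shows that in this series, the size of the step measured on one core cannot simply be carried over to another. It does not show why, since the two steps differ in both core and place, and two pairs of compounds give no general rule.

The compounds shown leave open whether a different group at the place filled in compound 4, such as an amine or an ethoxy group, would give a step of similar size. They also leave open how a longer chain there would compare.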